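Working notes: benzoyl for 4-methylbenzyl, compound 3 to compound 4

The source may hold more compounds than are shown below. What is called first, only, known or untested is meant among the compounds shown, and "the series" means these compounds.

Compound 1 `O=c1ccn(C2C=CC(O)C2)c(=O)n1Cc1ccccc1` reaches only a limit in an ADME assay on CCRF-CEM cells (Homo sapiens) for cytotoxicity, with a stated time of 3 days (a lower number here means that less compound is tolerated, a higher number that more compound is tolerated), > 250000 nM. Compound 2 `Cc1cc(=O)n(Cc2ccccc2)c(=O)n1C1C=CC(OC(=O)c2ccccc2)C1` gives 34000 nM in this assay, and compound 3 `Cc1ccc(Cn2c(=O)cc(C)n(C3C=CC(OC(=O)c4ccccc4)C3)c2=O)cc1` gives 20000 nM. Among the two numbers shown, compound 3 sits at the lower end, separated from compound 2 by a 1.7-fold lower number from compound 2 to compound 3 (0.23 log units; within the scatter), a gap that stays within the scatter. Compound 4 `Cc1cc(=O)n(C(=O)c2ccccc2)c(=O)n1C1C=CC(OC(=O)c2ccccc2)C1` differs from compound 3 by benzoyl in place of 4-methylbenzyl on an aromatic nitrogen. Within the data shown here, no measured step bears on this exchange; the single measured step concerns methyl in place of hydrogen on an aromatic carbon and is within the scatter. For this assay no step beyond the scatter is therefore expected. Compound 4 is estimated at 30000 nM with a range of 8000 nM to 120000 nM, an expected step of a 1.5-fold higher number from compound 3 to compound 4 (0.18 log units; within the scatter).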

Compound 4, half-maximal cytotoxic concentration: 191000 nM
Beside the measured number, compound 4's estimate is 6.4-fold (0.80 log units) below it, outside the stated range (above it).
By their numbers in this assay, from the lowest: compounds 3 and 2 (each within the scatter of the next); then compound 4. At a limit, above all of these: compound 1.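

On the aromatic nitrogen, benzoyl gives a clearly higher number than either benzyl-type group in this assay: a 9.6-fold higher number from compound 3 to compound 4 (0.98 log units; beyond the scatter), and a 5.6-fold higher number from compound 2 to compound 4 (0.75 log units; beyond the scatter). The heavy-atom count of the group stays the same between compound 3 and compound 4, so this position responds to the change of group and not to its count alone. Compound 4 remains a measured number, and only compound 1 stands at a limit: the limit of > 250000 nM in this assay, at which 1 of the 4 values shown sits.

From the compounds shown here alone, whether the carbonyl alone carries this step stays open. An acetyl, a benzenesulfonyl or a longer chain on this nitrogen would test that.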